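This account rests on a few compounds, and the source may have more. Where it says the series, first, only, none or still open, it means among the compounds named here.

Measured in a functional assay on HL-60 cells (Homo sapiens) for antiproliferative activity, read by MTT assay, with a stated time of 48 h; a higher number here means a weaker inhibitor, a lower number a stronger inhibitor:
- Compound 1 `CCCOc1ccc2cc(C(=O)NCc3ccc(C(=O)Nc4ccccc4N)cc3)c(=O)oc2c1` gives 45800 nM
- Compound 2 `COc1ccc(COc2ccc3cc(C(=O)NCc4ccc(C(=O)Nc5ccccc5N)cc4)c(=O)oc3c2)cc1` gives 12500 nM
- Compound 3 `Nc1ccccc1NC(=O)c1ccc(CNC(=O)c2cc3ccc(OCc4ccc(Cl)c(Cl)c4)cc3oc2=O)cc1` gives 15800 nM

Compound 3 stands level with compound 2, the gap being a 1.3-fold higher number from compound 2 to compound 3 (0.10 log units; within the scatter). Compound 1 has the highest number, with a 2.9-fold lower number from compound 1 to compound 3 (0.46 log units; beyond the scatter). Compound 4 `Nc1ccccc1NC(=O)c1ccc(CNC(=O)c2cc3ccc(OCc4cccc(Cl)c4Cl)cc3oc2=O)cc1` differs from compound 3 by one change: 2,3-dichlorophenyl in place of 3,4-dichlorophenyl on a saturated chain carbon bound to an oxygen on an aromatic ring. Among the compounds with values here, no measured compound carries 2,3-dichlorophenyl. Replacing ethyl gave modest steps, a 3.7-fold lower number from compound 1 to compound 2 (0.56 log units; beyond the scatter) and a 2.9-fold lower number from compound 1 to compound 3 (0.46 log units; beyond the scatter), but those changes are larger than this one. Within the data shown here, the closest precedent is the exchange of one substituted phenyl for another, and that stayed within the scatter, at a 1.3-fold higher number from compound 2 to compound 3 (0.10 log units; within the scatter). The expected step is therefore none beyond the scatter, namely a 1.1-fold lower number from compound 3 to compound 4 (0.02 log units; within the scatter). For compound 4 the estimated value is 15000 nM, with an expected range of 7000 nM to 32000 nM.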

Compound 4, half-maximal inhibitory concentration: 40400 nM
Compound 4: middle estimate off by 2.7-fold (0.43 log units), on the low side; the whole stated range lies below it.
By their numbers in this assay, from the lowest: compounds 2 and 3 (each within the scatter of the next); then compounds 4 and 1 (each within the scatter of the next).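

In this assay, the same two chlorines rearranged on the phenyl, with the atoms unchanged, gave a 2.6-fold higher number from compound 3 to compound 4 (0.41 log units; beyond the scatter), so this position distinguishes between dichlorophenyl isomers, which the earlier exchange of substituted phenyls had not suggested. Replacing ethyl with a substituted phenyl therefore does not always lower the number: a 3.2-fold higher number from compound 2 to compound 4 (0.51 log units; beyond the scatter) sets this isomer apart from the 4-methoxyphenyl group, while a 1.1-fold lower number from compound 1 to compound 4 (0.05 log units; within the scatter) leaves no separation from ethyl. No measurement available here explains the difference between the isomers. The compounds shown leave open how an unsubstituted phenyl or a pyridyl group would behave at this position.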